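The compounds below may be only part of what the source reports. "The series", "measured", "known", "first", "only" and "open" are said of these compounds alone.

Measured so far in a functional assay on cells (Melanoma cell, Homo sapiens) for cytotoxicity, read by sulforhodamine B assay, with a stated time of 48 h; a higher number here means a weaker inhibitor of growth, a lower number a stronger inhibitor of growth:
compound 1 `COc1ccc(C2CC(c3ccccc3)=NN2C2=NC(=O)/C(=C3\C(=O)Nc4ccc(Br)cc43)S2)cc1` gives 210 nM
compound 2 `COc1ccc(C2=NN(C3=NC(=O)/C(=C4\C(=O)Nc5ccc(Br)cc54)S3)C(c3ccc(OC)cc3)C2)cc1` gives 190 nM
compound 3 `COc1ccc(C2CC(c3ccc4ccccc4c3)=NN2C2=NC(=O)/C(=C3\C(=O)Nc4ccccc43)S2)cc1` gives 4800 nM

Compound 3 stands at the highest number of the three, beyond the scatter from both compound 1 and compound 2, which sit close together in this assay. Among the measured compounds shown here, the only single-point step measured is a 1.1-fold lower number from compound 1 to compound 2 (0.04 log units; within the scatter), a change at a different place on the shared core.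

Compound 4 `COc1ccc(C2CC(c3ccc4ccccc4c3)=NN2C2=NC(=O)/C(=C3\C(=O)Nc4ccc(Br)cc43)S2)cc1` differs from compound 3 by bromo in place of hydrogen on an aromatic carbon. For the measured compounds named here, no measured step isolates this exchange. Going by the values given here, compound 1 and compound 3 differ in two places at once, so their values show only that the compound carrying bromo, together with a second change, lies far below compound 3; how much of that gap belongs to bromo alone cannot be read from the data. The methoxy step gives no guidance on a bromo exchange.

Compound 4 is therefore expected to sit somewhat below compound 3, an expected step of a 2.7-fold lower number from compound 3 to compound 4 (0.43 log units; beyond the scatter), with wide uncertainty. The estimate for compound 4 is 1800 nM, range 400 nM to 7000 nM.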

Compound 4, concentration for 50% growth inhibition: 69 nM
The estimate for compound 4 lay 26-fold (1.42 log units) above the measured number; the whole stated range lies above it.
By their numbers in this assay, from the lowest: compound 4; then compounds 2 and 1 (each within the scatter of the next); then compound 3.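

In this assay, the exchange of hydrogen for bromo on the aromatic carbon meta to a fused ring and para to a fused ring is now isolated, and the step is large: a 70-fold lower number from compound 3 to compound 4 (1.84 log units; beyond the scatter). With bromo held in place, the exchanges at the carbon with a double bond to nitrogen are modest by comparison, naphthalen-2-yl in place of phenyl giving a 3.0-fold lower number from compound 1 to compound 4 (0.48 log units; beyond the scatter) and naphthalen-2-yl in place of 4-methoxyphenyl giving a 2.8-fold lower number from compound 2 to compound 4 (0.44 log units; beyond the scatter), so among these compounds the bromo step is the largest. Nothing available here accounts for the size of the bromo step.

Only one bromo exchange is shown, with naphthalen-2-yl as the partner, so its size with phenyl or 4-methoxyphenyl remains open. Also open, from the compounds shown here alone, is whether chloro, methyl or nitrile on the same carbon would give a comparable step.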